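The source may report more compounds than this note shows. Statements on the series, on what has been measured and on what is new or still open speak of the compounds shown alone.

In a functional assay on DLD-1 cells (Homo sapiens) for cytotoxicity, with a stated time of 48 h (a higher number here means a weaker inhibitor, a lower number a stronger inhibitor), three close relatives of a shared core have been measured. Compound 1 `COc1cccc2c(=O)cc(/C=C/[S+](C)[O-])oc12` gives 9000 nM in this assay. Compound 3 `COc1ccc2c(=O)cc(/C=C/[S+](C)[O-])oc2c1` gives 7800 nM in this assay. Compound 2 `CCOc1ccc2oc(/C=C/[S+](C)[O-])cc(=O)c2c1` gives 4900 nM in this assay, the lowest of the three numbers shown; its gap to compound 3 and its gap to compound 1 both lie within the usual scatter of repeated measurements, so the three values cannot be put in any order.

The next compound in the series is compound 4 `CC(C)COc1ccc2oc(/C=C/[S+](C)[O-])cc(=O)c2c1`, which is compound 2 with one change at the alkoxy chain: isopropyl in place of methyl on a saturated chain carbon bound to an oxygen on an aromatic ring. For the measured compounds named here, no measured pair in this set separates on the same change, so the size of its effect rests on expectation alone. The values of compound 3 and compound 2 show that lengthening the chain by a single carbon did not move the number beyond the scatter, and a further growth of the same chain is expected to behave in a similar way, with at most a modest lowering of the number. Compound 4 is therefore expected to give 3500 nM in this assay, within a range from 1200 nM to 10000 nM. The step from compound 2 to compound 4 is expected to be a 1.4-fold lower number from compound 2 to compound 4 (0.15 log units; within the scatter).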

Compound 4, half-maximal inhibitory concentration: 5000 nM
Beside the measured number, compound 4's estimate is 1.4-fold (0.15 log units) below it; the range from low to high includes it.
By their numbers in this assay, from the lowest: compounds 2, 4, 3 and 1 (each within the scatter of the next).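

In this assay, isopropyl in place of methyl on a saturated chain carbon bound to an oxygen on an aromatic ring gives a 1.0-fold higher number from compound 2 to compound 4 (0.01 log units; within the scatter), so ethoxy and isobutoxy cannot be told apart by this read-out. For the compounds shown here, this is the first pair in the set that differs in one place, and it gives a direct reading that the earlier compounds could not: at this place, the added carbons and the branch leave the number where it was, as far as the assay can tell. No supporting measurement is available to explain this result.

On these data alone, the two compounds therefore mark only a short stretch of chain, and it remains open whether a longer chain such as n-hexyl, a ring such as benzyl, or a chain ending in an amine or a carboxylic acid would move the number beyond the scatter at this place. Also open, as far as these compounds go, is whether the same change made on the core of compound 1 or compound 3 would read the same way as it does on the core of compound 2.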